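The source may report more compounds than this note shows. Statements on the series, on what has been measured and on what is new or still open speak of the compounds shown alone.

Compound 1 `O=c1n(Cc2nc(-c3nccs3)cn2CCCCO)c2cnccc2n1C1CC1` stands highest of the two compounds measured in a physicochemical assay for lipophilicity, measured as octanol-water partition, at pH 7.4; on this read-out lower numbers stand for lower lipophilicity and higher numbers for higher lipophilicity: compound 1 gives 1.3, whereas compound 2 `COC(=O)c1nc(Cn2c(=O)n(C3CC3)c3ccncc32)n(CCCCO)c1C` gives 0.8, a gap that lies beyond the usual scatter of this assay. Compound 3 `O=c1n(Cc2nc(-c3ncccn3)cn2CCCCO)c2cnccc2n1C1CC1` has not yet been measured in this assay. It differs from compound 1 in one place, by pyrimidin-2-yl in place of 1,3-thiazol-2-yl on an aromatic carbon; the rest of the molecule, including the shared core and the 4-hydroxybutyl group, is unchanged. Among the measured compounds shown here, no measured pair shows this particular exchange, so the size of the step has to be guessed from the change itself rather than from any measured step. The step expected in this assay, a number 0.60 log units lower from compound 1 to compound 3 (beyond the scatter), is a moderate fall, likely beyond the scatter. On that basis compound 3 is estimated at 0.7, within a range from 0.2 to 1.2.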

Compound 3, distribution coefficient: 0.6
Beside the measured number, compound 3's estimate is 0.10 log units above it; measured number inside the range.
By their numbers in this assay, from the lowest: compounds 3 and 2 (each within the scatter of the next); then compound 1.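

In this assay the exchange of 1,3-thiazol-2-yl for pyrimidin-2-yl on this aromatic carbon gives a number 0.70 log units lower from compound 1 to compound 3 (beyond the scatter) as the first step read at this position. The read-out therefore responds to a change at this position alone, with the shared core and the 4-hydroxybutyl group left as they were, although both groups have the same counts of hydrogen-bond donors and acceptors and no net charge. No measurement at hand accounts for the size of this step.

This single pair cannot separate the change from a five-membered to a six-membered ring from the loss of the sulfur. Going by these compounds, how a phenyl or pyridin-2-yl group, or an amine, would stand at this aromatic carbon in this assay remains open.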